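A Second Chloro Added to the 3-Chlorophenyl Ring

The compounds below may be only part of what the source reports. "The series", "measured", "known", "first", "only" and "open" are said of these compounds alone.

compound 1 `O=C(CCCc1ccccc1)Nc1nc2cc(Cl)ccc2c(=O)s1` – 91.6 nM
compound 2 `O=C(C/C=C/c1ccccc1)Nc1nc2ccccc2c(=O)s1` – 158 nM
compound 3 `O=C(C/C=C/c1cccc(Cl)c1)Nc1nc2ccccc2c(=O)s1` – > 1000 nM (a limit of the assay, not a number)

All three were tested in an assay on CHO cells for displacement of a labelled ligand from adenosine receptor A3 (Homo sapiens), read by scintillation counting, with a stated time of 60 min; on this read-out higher numbers stand for weaker inhibition and lower numbers for stronger inhibition. Compound 1 carries its chloro on the shared core and gives 91.6 nM. Compound 2, with an unsubstituted phenyl on the unsaturated chain, gives 158 nM. Compound 3 stands only at a limit of this assay, > 1000 nM, so no true number is known for it.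

Compound 4 `O=C(C/C=C/c1ccc(Cl)c(Cl)c1)Nc1nc2ccccc2c(=O)s1` has not yet been measured. It differs from compound 3 by chloro in place of hydrogen on an aromatic carbon. Among the measured compounds shown here, the only measured step that bears on this change is an at least 6.3-fold higher number from compound 2 to compound 3 (0.80 log units; beyond the scatter), the first chloro on the same phenyl; its true size is not known because compound 3 sits at the limit of > 1000 nM in this assay, at which 1 of the 3 values shown sits. Compound 1 offers no guidance, as its chloro sits on the core rather than on the phenyl.

A second chloro on a ring where the first already pushed binding past the limit is expected to give no recovery; compound 4 is expected to sit at or beyond the same limit, with the step from compound 3 estimated as a step that the limit leaves unreadable from compound 3 to compound 4. The estimate for compound 4 is 2500 nM, in a range from 800 nM to 10000 nM.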

Compound 4, inhibition constant: > 1000 nM
Compound 4: no number, only a limit; the forecaster's own chance of this, stated with the estimate: 75%; the middle value does not contradict the limit.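

In this assay compound 4 gives > 1000 nM, which is a limit of the assay and not a number. This shows that a chloro placed ortho to a chloro group and para to a large group on the phenyl ring does not bring binding back into the range this assay can read, so the loss seen with the 3-chlorophenyl group persists with the 3,4-dichlorophenyl group, and the comparison with the unsubstituted phenyl gives an at least 6.3-fold higher number from compound 2 to compound 4 (0.80 log units; beyond the scatter). What the second chloro itself adds cannot be read, as compound 3 and compound 4 stop at the same limit, and the step between them therefore has no size: the limit of > 1000 nM in this assay, at which 2 of the 4 values shown sit.

On these data alone, the true values of compound 3 and compound 4 remain unknown, so it stays open whether the second chloro weakens binding further, leaves it unchanged, or improves it slightly without reaching the readable range. Also open, as far as these compounds go, is whether an amine or a methoxy group in place of the chloro on this phenyl ring would stay close to compound 2, which gives 158 nM.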